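Chloro for Trifluoromethyl on the Benzoate Ring

The source may hold more compounds than are shown below. What is called first, only, known or untested is meant among the compounds shown, and "the series" means these compounds.

Compound 2 `CC1=CC[C@H](C(C)C)c2cc(C)c(OC(=O)c3ccc(C(F)(F)F)cc3)cc21` stands lowest of the two compounds measured in a functional assay on PC-3 cells (Homo sapiens) for antiproliferative activity, read by sulforhodamine B assay, with a stated time of 48 h, tested at 50 uM (on this read-out higher numbers stand for more inhibition at the one concentration tested (going by the name of the read-out) and lower numbers for less inhibition), where compound 2 gives 12.3%; compound 1 `CC1=CC[C@H](C(C)C)c2cc(C)c(OC(=O)c3ccccc3)cc21` gives 22.5%. Compound 3 `CC1=CC[C@H](C(C)C)c2cc(C)c(OC(=O)c3ccc(Cl)cc3)cc21` has not yet been measured; it differs from compound 2 by chloro in place of trifluoromethyl on an aromatic carbon. Among the compounds with values here, the only measured step that bears on this change is a number 10.2 percentage points lower from compound 1 to compound 2 (beyond the scatter), which shows that putting trifluoromethyl at this place lowered the inhibition. Replacing it with chloro is therefore expected to give a step of a number 4.7 percentage points higher from compound 2 to compound 3 (within the scatter), upward but small. Compound 3 is estimated at 17%, with a range from 5% to 30%.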

Compound 3, a percentage reported as inhibition, at one concentration (the size of the read-out at that concentration, not a potency): 34.1%
The estimate for compound 3 lay 17.1 percentage points below the measured number; the whole stated range lies below it.
By their numbers in this assay, from the lowest: compound 2; then compound 1; then compound 3.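

Within the data shown here, the earlier compounds showed only that a group at this position could lower the inhibition, but in this assay chloro raises it, with a number 11.6 percentage points higher from compound 1 to compound 3 (beyond the scatter) when chloro replaces hydrogen. The outcome here therefore depends on which group is present, and exchanging trifluoromethyl for chloro gives a number 21.8 percentage points higher from compound 2 to compound 3 (beyond the scatter) in the same read-out. Nothing given here accounts for this difference between the two groups.

From the compounds shown here alone, whether an amine, a carboxylic acid or a longer chain at this position would raise or lower the inhibition remains open. The order of these compounds at other concentrations also remains open, since the read-out gives no potency.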